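The source may report more compounds than this note shows. Statements on the series, on what has been measured and on what is new or still open speak of the compounds shown alone.

For the measured compounds named here, in a functional assay on NCI-H23 cells (Homo sapiens) for inhibition, read by sulforhodamine B assay, with a stated time of 48 h (a lower number here means a stronger inhibitor of growth, a higher number a weaker inhibitor of growth), compound 1 `Cc1ccc(NC(=O)/C=C/c2ccccc2)c(C(N)=O)c1` gives 3380 nM and compound 2 `NC(=O)c1cc(Br)ccc1NC(=O)/C=C/c1ccccc1` gives 1090 nM, the lower of the two numbers so far. Next is compound 3 `NC(=O)c1cc(I)ccc1NC(=O)/C=C/c1ccccc1`, with iodo in place of bromo on an aromatic carbon. Going by the values given here, one measured step bears on this change, at the same aromatic carbon: a 3.1-fold lower number from compound 1 to compound 2 (0.49 log units; beyond the scatter), modest and beyond the scatter. Among the compounds with values here, with only that step as a guide, a small further drop or none beyond the scatter is expected in this assay. The expected change is a 1.3-fold lower number from compound 2 to compound 3 (0.11 log units; within the scatter). The estimate for compound 3 is 850 nM, with an expected range of 380 nM to 1900 nM.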

Compound 3, concentration for 50% growth inhibition: 840 nM
The estimate for compound 3 lay 1.0-fold (0.01 log units) above the measured number; measured number inside the range.
By their numbers in this assay, from the lowest: compounds 3 and 2 (each within the scatter of the next); then compound 1.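

In this assay, iodo and bromo cannot be told apart at this position, para to a large group: a 1.3-fold lower number from compound 2 to compound 3 (0.11 log units; within the scatter). Replacing methyl with iodo gives a 4.0-fold lower number from compound 1 to compound 3 (0.60 log units; beyond the scatter), so both halogens shown stand clear of methyl, with no further step from bromo to iodo beyond the scatter. Nothing measured here explains these steps. Still open, on these data alone, is how chloro, fluoro, an amine or a carboxylic acid would read on this aromatic carbon. Also open, as far as these compounds go, is whether bromo and iodo stay level when another part of the shared core changes.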